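The source may hold more compounds than are shown below. What is called first, only, known or untested is meant among the compounds shown, and "the series" means these compounds.

Measured so far in a functional assay on PC-3 cells (Homo sapiens) for inhibition, read by MTT assay, with a stated time of 48 h; on this read-out higher numbers stand for weaker inhibition of growth and lower numbers for stronger inhibition of growth:
compound 1, `C#CCN(C)Cc1cccc(NC(=O)CCCC(=O)NO)c1`, with > 10000 nM
compound 2, `C#CCN(C)Cc1cccc(NC(=O)CCCCCCCCC(=O)NO)c1`, with 1790 nM
compound 3, `C#CCN(C)Cc1ccc(NC(=O)CCCC(=O)NO)cc1`, with > 10000 nM

Compound 3 stands at a limit of this assay rather than at a number: for compound 3 only the limit > 10000 nM is known. The same limit holds for compound 1, which also gives only > 10000 nM in this assay. Both sit at the limit of > 10000 nM in this assay, at which 2 of the 3 values shown sit, so the two short-chain compounds cannot be placed against each other beyond the fact that neither reaches a number.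

The next compound, compound 4 `C#CCN(C)Cc1ccc(NC(=O)CCCCCCCC(=O)NO)cc1`, differs from compound 3 in one place: 4-(hydroxycarbamoyl)butyl in place of hydroxycarbamoyl on a saturated chain carbon, three bonds along the chain from a carbonyl carbon. The chain is lengthened while the hydroxamic acid end and the shared core are kept.

Within the data shown here, one measured step bears on this change. Within the other core, the step of an at least 5.5-fold lower number from compound 1 to compound 2 (0.74 log units; beyond the scatter) turned a limit into a number, and the chain added there is longer by one carbon than the one added here. A step of similar kind, downward in this assay, is therefore expected for compound 4, with some chance that compound 4 still remains at the limit. The expected step is an at least 4.0-fold lower number from compound 3 to compound 4 (0.60 log units; beyond the scatter). Compound 4 is estimated at 2500 nM, between 700 nM and 9000 nM.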

Compound 4, concentration for 50% growth inhibition: 7160 nM
For compound 4 the middle estimate is 2.9-fold (0.46 log units) below the measured one; the range from low to high includes it.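

In this assay, lengthening the chain now gives a number in place of a limit on the shared core of compound 3 and compound 4, so this outcome is no longer confined to the core of compound 1. The change, 4-(hydroxycarbamoyl)butyl in place of hydroxycarbamoyl on a saturated chain carbon, gives an at least 1.3-fold lower number from compound 3 to compound 4 (0.14 log units; that floor lies within the scatter), which means that only a floor for the step is known and that this floor alone does not establish a change beyond the usual scatter. Compound 3 gives only a limit, and the true size of the step stays unknown because the starting point is not a number: the limit of > 10000 nM in this assay, at which 2 of the 4 values shown sit.

What the compounds shown leave open is whether a still longer chain on the core of compound 3 would carry the number further down, or whether the trend would stop or reverse at some chain length. They also leave open whether the chain effect depends on the hydroxycarbamoyl end, since a carboxylic acid at that end of the same chain could show whether the gain stays in place.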